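Ether-to-thioether change on the shared core

The source may report more compounds than this note shows. Statements on the series, on what has been measured and on what is new or still open speak of the compounds shown alone.

Compound 1 `Nc1cc(N)c2nc(-c3ccccc3)c(Oc3ccc(Cl)c(Cl)c3)nc2c1` and compound 2 `COc1cc(CNc2nc3cc(N)cc(N)c3nc2-c2ccccc2)cc(OC)c1OC` share one core and were both run in a functional assay on K562 cells (Homo sapiens) for inhibition, read by sulforhodamine B assay, with a stated time of 48 h; a lower number here means that less compound is tolerated, a higher number that more compound is tolerated. Compound 1 gives < 100000 nM, which is a limit of the assay rather than a number (the limit of < 100000 nM in this assay, at which 1 of the 2 values shown sits). Compound 2 gives < 50200 nM, likewise a limit rather than a number (the limit of < 50200 nM in this assay, at which 1 of the 2 values shown sits). Going by the values given here, compound 1 therefore stands only at a limit, and the two values together give no step that can be sized; they show only that each compound sits at its own limit. Compound 3 `Nc1cc(N)c2nc(-c3ccccc3)c(Sc3ccc(Cl)c(Cl)c3)nc2c1` differs from compound 1 in one place: (3,4-dichlorophenyl)sulfanyl in place of 3,4-dichlorophenoxy on an aromatic carbon. Among the compounds with values here, no measured step covers this change, so the expectation is a step that the limit leaves unreadable from compound 1 to compound 3, none beyond the scatter and in no particular direction. For compound 3 the expected value in this assay is estimated at 40000 nM, with a range from 8000 nM to 150000 nM.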

Compound 3, concentration lethal to 50% of the cells: < 100000 nM
Compound 3 was reported as a limit; the forecaster's own chance of this, stated with the estimate: 50%; the middle value lies beyond the limit too.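

Going by these compounds alone, compound 1 and compound 3 both stand only at a limit in this assay, and no step between them can be read. Going by these compounds, whether (3,4-dichlorophenyl)sulfanyl in place of 3,4-dichlorophenoxy shifts the lethal concentration at all, and in which direction, stays open.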